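Replacing Trifluoromethyl with Dimethylamino on a Shared Core

A few compounds are considered here, and "the series" means these few. Any claim that something is new, unique, unknown or untested is made for them only; others in the source may bear on it.

Of the compounds shown here, three built on one shared core have so far been measured in a functional assay with Rattus norvegicus as the target; on this read-out higher numbers stand for weaker inhibition and lower numbers for stronger inhibition. Compound 1 `O=C(/C=C/c1ccncc1)c1ccc(Cl)cc1` gives 60000 nM, compound 2 `O=C(/C=C/c1ccncc1)c1ccccc1` gives 49000 nM, and compound 3 `O=C(/C=C/c1ccncc1)c1ccc(C(F)(F)F)cc1` gives 204000 nM. Compound 3 therefore stands at the highest number of the three, which on this read-out means the weakest inhibition, and its steps to compound 1 and compound 2 both lie beyond the scatter. Between compound 1 and compound 2 the step of a 1.2-fold lower number from compound 1 to compound 2 (0.09 log units; within the scatter) is within the scatter.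

Compound 4 `CN(C)c1ccc(C(=O)/C=C/c2ccncc2)cc1` has not yet been measured. It differs from compound 3 in one place: dimethylamino in place of trifluoromethyl on an aromatic carbon. Within the data shown here, two measured steps bear on this change, since both describe trifluoromethyl arriving on that aromatic carbon: a 3.4-fold higher number from compound 1 to compound 3 (0.53 log units; beyond the scatter) and a 4.2-fold higher number from compound 2 to compound 3 (0.62 log units; beyond the scatter), each a modest rise. Taking trifluoromethyl away again would be expected to undo a rise of that size. Nothing measured here shows what dimethylamino itself does on that carbon, so the range must be wide. The expected step is a 4.1-fold lower number from compound 3 to compound 4 (0.61 log units; beyond the scatter), a modest fall that would place compound 4 close to compound 1 and compound 2. Compound 4 is estimated at 50000 nM, between 15000 nM and 160000 nM.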

Compound 4, half-maximal inhibitory concentration: 11000 nM
For compound 4 the middle estimate is 4.5-fold (0.66 log units) above the measured one; measured number outside the range, below it.
By their numbers in this assay, from the lowest: compound 4; then compounds 2 and 1 (each within the scatter of the next); then compound 3.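

In this assay, dimethylamino is the only group shown on this aromatic carbon that clearly moves the number down, toward stronger inhibition, with a 4.5-fold lower number from compound 2 to compound 4 (0.65 log units; beyond the scatter) when it replaces hydrogen and a 5.5-fold lower number from compound 1 to compound 4 (0.74 log units; beyond the scatter) when it replaces chloro. The position can therefore shift the read-out in either direction from hydrogen, since trifluoromethyl raises the number and dimethylamino lowers it, and exchanging one for the other gives a 19-fold lower number from compound 3 to compound 4 (1.27 log units; beyond the scatter), the largest step among these compounds and one that leaves compound 4 as the strongest inhibitor of the four. No measurement of any property of these groups is available to account for this difference.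

With only hydrogen, chloro, trifluoromethyl and dimethylamino shown on this carbon, it remains open whether the fall depends on the two methyl groups or on the nitrogen alone, a question that a plain amine, a methylamino group or a diethylamino group in the same place could help to settle. As far as these compounds go, it also remains open whether dimethylamino would give a similar step on a different carbon of the same aromatic ring.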